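The compounds below may be only part of what the source reports. "The series", "measured", "known", "first", "only" and "open" are said of these compounds alone.

Compound 3 `CCCCCCCCCCCCCCNC(=O)[C@H](CO)/N=C/c1ccccc1C` gives 87700 nM in a functional assay on cells (Homo sapiens) for cytotoxicity, read by MTT assay, with a stated time of 24 h; a higher number here means a weaker inhibitor, a lower number a stronger inhibitor. Compound 1 `CCCCCCCCCCCCCCNC(=O)[C@H](CO)NCc1ccccc1OC` gives 100000 nM and compound 2 `CCCCCCCCCCCCCCNC(=O)[C@H](CO)/N=C/c1cccc([N+](=O)[O-])c1` gives 104000 nM; compound 3 holds the lowest of the three numbers, but the steps to it, a 1.1-fold lower number from compound 1 to compound 3 (0.06 log units; within the scatter) and a 1.2-fold lower number from compound 2 to compound 3 (0.07 log units; within the scatter), are both within the scatter, so the three compounds sit together. Compound 4 `CCCCCCCCCCCCCCNC(=O)[C@H](CO)/N=C/c1ccccc1Cl` differs from compound 3 by chloro in place of methyl on an aromatic carbon. Within the data shown here, no measured step alters a single substituent on this ring; the two steps at hand exchange whole groups, as in a 1.2-fold lower number from compound 2 to compound 3 (0.07 log units; within the scatter), and neither moves the number beyond the scatter. The expected step of a 1.0-fold higher number from compound 3 to compound 4 (0.00 log units; within the scatter) is accordingly none beyond the scatter. Compound 4 is therefore estimated at 88000 nM, within 40000 nM to 190000 nM, in this assay.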

Compound 4, half-maximal inhibitory concentration: 10300 nM
The estimate for compound 4 lay 8.5-fold (0.93 log units) above the measured number, and the stated range ends above it.
By their numbers in this assay, from the lowest: compound 4; then compounds 3, 1 and 2 (each within the scatter of the next).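

In this assay, among these compounds, chloro in place of methyl on an aromatic carbon ortho to a large group is the first change to move the number beyond the scatter (an 8.5-fold lower number from compound 3 to compound 4 (0.93 log units; beyond the scatter)). The exchanges of whole groups leading to compound 4 are also beyond the scatter (a 10-fold lower number from compound 2 to compound 4 (1.00 log units; beyond the scatter); a 9.7-fold lower number from compound 1 to compound 4 (0.99 log units; beyond the scatter)), so compound 4 separates from the other three. Nothing measured here accounts for this separation.

Going by these compounds, whether bromo or trifluoromethyl at this place retains the lower number remains open. So does whether chloro retains it on a shorter chain.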